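The compounds below may be only part of what the source reports. "The series", "measured", "known", "first", "only" and "open" are said of these compounds alone.

Compound 1 `COc1ccc(Cn2cc(/C=C(\C#N)C(=O)c3c[nH]c4cc(OC)ccc34)c3ccccc32)cc1` is reported in a functional assay on PC-3 cells (Homo sapiens) for cytotoxicity, read by WST assay, with a stated time of 48 h (a lower number here means a stronger inhibitor, a higher number a weaker inhibitor), at > 50000 nM, which is a limit of the assay and not a number. Compound 2 `N#C/C(=C\c1c[nH]c2ccccc12)C(=O)c1c[nH]c2ccccc12` gives > 50000 nM, likewise only a limit. Compound 3 `COc1ccc(-c2[nH]c3ccccc3c2/C=C(\C#N)C(=O)c2c[nH]c3ccccc23)cc1` gives 8100 nM.

Compound 2 thus stands at the limit of > 50000 nM in this assay, at which 2 of the 3 values shown sit, with no number of its own. Compound 4 `COc1ccc(Cn2cc(/C=C(\C#N)C(=O)c3c[nH]c4ccccc34)c3ccccc32)cc1` differs from compound 2 by 4-methoxybenzyl in place of hydrogen on an aromatic nitrogen. Going by the values given here, the one measured step that bears on this is an at least 6.1-fold lower number from compound 2 to compound 3 (0.79 log units; beyond the scatter), where the same group, placed on a carbon instead, brought a clear gain. Compound 1 carries the very same benzyl group on its nitrogen and gives only a limit. A modest step of an at least 1.4-fold lower number from compound 2 to compound 4 (0.15 log units; that floor lies within the scatter) is expected, and compound 4 is estimated at 35000 nM, between 8000 nM and 60000 nM.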

Compound 4, half-maximal inhibitory concentration: > 50000 nM
Compound 4 gave a limit, no number (the forecaster's own chance of this, stated with the estimate: 55%); middle value at least 1.4-fold (0.15 log units) away from the limit.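

The steps to compound 4 from compound 2 and from compound 1 cannot be read, as all three compounds give only a limit of the assay: the limit of > 50000 nM in this assay, at which 3 of the 4 values shown sit.

Going by these compounds, whether 4-methoxybenzyl on the aromatic nitrogen changes the number in this assay at all stays open.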